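From Cyanophenyl to Thiophene on a Shared Core

A few compounds are considered here, and "the series" means these few. Any claim that something is new, unique, unknown or untested is made for them only; others in the source may bear on it.

Three compounds built on one core were tested in an assay for inhibition of Thromboxane-A synthase (Homo sapiens), using microsomes; a lower number here means a stronger inhibitor, a higher number a weaker inhibitor. Compound 1 `N#Cc1ccc(C2OCC(C/C=C\CCC(=O)O)C(c3cccnc3)O2)cc1` gives 24 nM, the lowest of the three numbers. Compound 2 `N#Cc1ccccc1C1OCC(C/C=C\CCC(=O)O)C(c2cccnc2)O1` gives 54 nM, and compound 3 `O=C(O)CC/C=C\CC1COC(c2ccc(C(F)(F)F)cc2)OC1c1cccnc1` gives 44 nM. The step of a 2.3-fold higher number from compound 1 to compound 2 (0.35 log units; beyond the scatter) is modest and lies beyond the scatter, whereas the step of a 1.8-fold higher number from compound 1 to compound 3 (0.26 log units; within the scatter) stays within it; compound 2 and compound 3 differ by a 1.2-fold lower number from compound 2 to compound 3 (0.09 log units; within the scatter), also within the scatter. Compound 4 `O=C(O)CC/C=C\CC1COC(c2cccs2)OC1c1cccnc1` has not yet been measured. Its difference from compound 1 is thiophen-2-yl in place of 4-cyanophenyl on a saturated ring carbon. The two measured changes of this same group are the ones that bear on it, and both moved the number upward. Since those changes gave a 2.3-fold higher number from compound 1 to compound 2 (0.35 log units; beyond the scatter) and a 1.8-fold higher number from compound 1 to compound 3 (0.26 log units; within the scatter), a rise of similar, modest size is expected for compound 4, namely a 2.1-fold higher number from compound 1 to compound 4 (0.32 log units; beyond the scatter). In this assay compound 4 is therefore estimated at 50 nM, within a range from 20 nM to 130 nM.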

Compound 4, half-maximal inhibitory concentration: 71 nM
Estimate against measurement, compound 4: 1.4-fold (0.15 log units) below; measured number inside the range.
By their numbers in this assay, from the lowest: compounds 1, 3, 2 and 4 (each within the scatter of the next, the first and the last beyond it).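

In this assay, the saturated ring carbon between two ring oxygen atoms takes a five-membered aromatic ring as well as a six-membered one, with a 3.0-fold higher number from compound 1 to compound 4 (0.47 log units; beyond the scatter), a modest step. Thiophen-2-yl does not separate from the other two replacements at this position, since a 1.6-fold higher number from compound 3 to compound 4 (0.21 log units; within the scatter) and a 1.3-fold higher number from compound 2 to compound 4 (0.12 log units; within the scatter) both stay within the scatter. The 4-cyanophenyl group of compound 1 thus stands beyond the scatter from thiophen-2-yl and 2-cyanophenyl, but not from the 4-(trifluoromethyl)phenyl group of compound 3.

No measurement shown here accounts for these steps. As far as these compounds go, whether a furan-2-yl group, an unsubstituted phenyl group or a phenyl group carrying an amine at this carbon would give a number in the same range remains open.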